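A few compounds are considered here, and "the series" means these few. Any claim that something is new, unique, unknown or untested is made for them only; others in the source may bear on it.

Working notes on the series. Compound 1 `O=C(Nc1ccc(Oc2cc(C(F)(F)F)cc(C(F)(F)F)c2)cc1)c1cc(Cl)ccc1F` gives 1110 nM in an assay on HEK293 cells for inhibition of Toll-like receptor 8 (Homo sapiens), with a stated time of 16 h (on this read-out lower numbers stand for stronger inhibition and higher numbers for weaker inhibition), and stands lowest of the two numbers shown. Compound 2 `O=C(Nc1ccc(Oc2cc(C(F)(F)F)cc(C(F)(F)F)c2)cc1)c1c(F)cccc1Br` gives 6000 nM in this assay. Compound 3 `O=C(Nc1ccc(Oc2cc(C(F)(F)F)cc(C(F)(F)F)c2)cc1)c1ccc(I)cc1F` returns only a limit in this assay, > 50000 nM, as noted in the limit of > 50000 nM in this assay, at which 1 of the 3 values shown sits. Both measured changes away from compound 1 run toward weaker inhibition: a 5.4-fold higher number from compound 1 to compound 2 (0.73 log units; beyond the scatter) and an at least 45-fold higher number from compound 1 to compound 3 (1.65 log units; beyond the scatter); between the two variants, an at least 8.3-fold higher number from compound 2 to compound 3 (0.92 log units; beyond the scatter).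

Compound 4 `O=C(Nc1ccc(Oc2cc(C(F)(F)F)cc(C(F)(F)F)c2)cc1)c1c(F)cccc1OC(F)(F)F` is not yet measured. It differs from compound 1 by a group of 12 heavy atoms (7 carbon, 1 oxygen, 4 fluorine; one six-membered aromatic ring of carbon only) in place of a group of 8 heavy atoms (6 carbon, 1 fluorine, 1 chlorine; one six-membered aromatic ring of carbon only), on a carbonyl carbon. The nearest measured step is a 5.4-fold higher number from compound 1 to compound 2 (0.73 log units; beyond the scatter), where the 5-chloro-2-fluorophenyl was likewise exchanged for another halogen-bearing phenyl with a substituent in place of the chlorine. Compound 3 shows that some exchanges at this carbonyl carbon push the number to the limit. A modest step toward weaker inhibition is therefore expected, a 7.2-fold higher number from compound 1 to compound 4 (0.86 log units; beyond the scatter). Compound 4 is expected to give about 8000 nM in this assay, within a range of 2500 nM to 30000 nM.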

Compound 4, half-maximal inhibitory concentration: > 50000 nM
Compound 4: only a limit was reported; the forecaster's own chance of this, stated with the estimate: 15%; at least 6.2-fold (0.79 log units) between middle value and limit.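

On this carbonyl carbon, the exchange of bromo for trifluoromethoxy on an aromatic carbon costs more than the earlier bromo-bearing group did in this assay: an at least 8.3-fold higher number from compound 2 to compound 4 (0.92 log units; beyond the scatter). Measured against the 5-chloro-2-fluorophenyl, the new group gives an at least 45-fold higher number from compound 1 to compound 4 (1.65 log units; beyond the scatter), so a second aryl group on the carbonyl carbon now goes beyond what the assay can read, and compound 1 keeps the lowest number shown. Compound 4 therefore joins compound 3 as a limit rather than a number: the limit of > 50000 nM in this assay, at which 2 of the 4 values shown sit.

With both values being limits, the step between compound 3 and compound 4 cannot be read. Still open, on these data alone, is whether methoxy or an amine in place of bromo on an aromatic carbon would give a number close to that of compound 2 or also reach the limit.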